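Fluorobenzyl substitution on a fluorouracil-sesquiterpene lactone conjugate

The source may report more compounds than this note shows. Statements on the series, on what has been measured and on what is new or still open speak of the compounds shown alone.

Measured compounds:
compound 1, `C=C1C(=O)O[C@H]2[C@H]1CC/C(COC(=O)Cn1cc(F)c(=O)n(Cc3ccccc3)c1=O)=C\CC[C@@]1(C)O[C@@H]21`, 4270 nM
compound 2, `C=C1C(=O)O[C@H]2[C@H]1CC/C(Cn1cc(Cn3cc(F)c(=O)n(Cc4ccccc4)c3=O)nn1)=C\CC[C@@]1(C)O[C@@H]21`, 8840 nM
compound 3, `C=C1C(=O)O[C@H]2[C@H]1CC/C(Cn1cc(Cn3cc(F)c(=O)n(Cc4ccc(F)cc4)c3=O)nn1)=C\CC[C@@]1(C)O[C@@H]21`, 4860 nM

Three conjugates have been measured in a functional assay on Bel7402/5-FU cells (Homo sapiens) for antiproliferative activity, read by MTT assay, with a stated time of 72 h; on this read-out higher numbers stand for weaker inhibition and lower numbers for stronger inhibition. Compound 1 gives 4270 nM, compound 2 gives 8840 nM and compound 3 gives 4860 nM. Compound 1 and compound 3 lie within the scatter of each other, while compound 1 shows a lower number than compound 2; the difference between the cores of compound 1 and compound 2 is not broken down here.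

Compound 4, `C=C1C(=O)O[C@H]2[C@H]1CC/C(COC(=O)Cn1cc(F)c(=O)n(Cc3ccc(F)cc3)c1=O)=C\CC[C@@]1(C)O[C@@H]21`, has not yet been measured. It differs from compound 1 by fluoro in place of hydrogen on an aromatic carbon. The same change, in the same place, is found in the measured pair where compound 3 differs from compound 2 by fluoro in place of hydrogen on an aromatic carbon, and there it made a 1.8-fold lower number from compound 2 to compound 3 (0.26 log units; within the scatter).

Because the measured step of a 1.8-fold lower number from compound 2 to compound 3 (0.26 log units; within the scatter) stays within the scatter, compound 4 is expected to sit close to compound 1, with a step of about a 1.4-fold lower number from compound 1 to compound 4 (0.15 log units; within the scatter). Compound 4 is therefore estimated at 3000 nM, between 1400 nM and 6500 nM.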

Compound 4, half-maximal inhibitory concentration: 1140 nM
For compound 4 the middle estimate is 2.6-fold (0.42 log units) above the measured one, and the stated range ends above it.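

In this assay, going from benzyl to 4-fluorobenzyl on the core of compound 1 gives a 3.7-fold lower number from compound 1 to compound 4 (0.57 log units; beyond the scatter). Set beside the same change on the other core, this step does not differ from the earlier one by more than the scatter of two such steps allows: the same change on two cores in this assay, a 1.8-fold lower number (0.26 log units; within the scatter) from compound 2 to compound 3 and a 3.7-fold lower number (0.57 log units; beyond the scatter) from compound 1 to compound 4, 2.1-fold (0.31 log units) apart, within the scatter of two such steps. This means the data give no sign that the size of the step depends on the core, but the change is clearly resolved only on the core of compound 1, and two pairs can neither fix a size for it nor show that it would carry over to any further core.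

The compounds shown leave open whether a chloro, methoxy or methyl group in the same place on the aromatic ring would give a step like that of fluoro. They also leave open whether the step would hold on a core joined to the rest of the molecule through a longer chain.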